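Varying the ring-nitrogen substituent of the rhodanine-type unit

The source may hold more compounds than are shown below. What is called first, only, known or untested is meant among the compounds shown, and "the series" means these compounds.

Compound 2 `CN1C(=O)/C(=C/N2N=C(c3ccccc3)CC2c2ccccc2O)SC1=S` gives 341 nM in a functional assay on SK-OV-3 cells (Homo sapiens) for antiproliferative activity, read by MTT assay, with a stated time of 72 h; on this read-out lower numbers stand for stronger inhibition and higher numbers for weaker inhibition. Among the two numbers measured so far it has the higher one; the nearest is compound 1 `CC(=O)Oc1ccc(N2C(=O)/C(=C/N3N=C(c4ccccc4)CC3c3ccccc3O)SC2=S)cc1`, which gives 244 nM, and the step of a 1.4-fold higher number from compound 1 to compound 2 (0.15 log units; within the scatter) stays within the scatter, so the two cannot be ordered. Compound 3 `O=C1/C(=C/N2N=C(c3ccccc3)CC2c2ccccc2O)SC(=S)N1c1cccnc1` shows only a limit in this assay, at > 10000 nM. Its step from compound 2, an at least 29-fold higher number from compound 2 to compound 3 (1.46 log units; beyond the scatter), and from compound 1, an at least 40-fold higher number from compound 1 to compound 3 (1.61 log units; beyond the scatter), are both large, and this is the only place where the substituent on the amide-type nitrogen has been seen to matter, because the limit of > 10000 nM in this assay, at which 1 of the 3 values shown sits, marks where compound 3 sits.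

Compound 4 `O=C1NC(=S)/C(=C/N2N=C(c3ccccc3)CC2c2ccccc2O)S1` has not been measured. The change from compound 2 is a group of 8 heavy atoms (4 carbon, 1 nitrogen, 1 oxygen, 2 sulfur; one five-membered non-aromatic ring with 2 hetero atoms) in place of a group of 9 heavy atoms (5 carbon, 1 nitrogen, 1 oxygen, 2 sulfur; one five-membered non-aromatic ring with 2 hetero atoms), on an amine nitrogen in a ring, on an amine nitrogen in a ring, next to the ring nitrogen. Of the measured steps, the methyl-to-aryl exchange bears most closely on it and was flat, while the pyridinyl exchange was large. For the measured compounds named here, no step shows what a free ring-nitrogen hydrogen does. The expectation in this assay is therefore a step from compound 2 that stays within the scatter or rises a little, a 1.6-fold higher number from compound 2 to compound 4 (0.21 log units; within the scatter). Compound 4 is estimated at 550 nM, within 150 nM to 3000 nM.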

Compound 4, half-maximal inhibitory concentration: 7870 nM
Compound 4: middle estimate off by 14-fold (1.16 log units), on the low side; the whole stated range lies below it.
By their numbers in this assay, from the lowest: compounds 1 and 2 (each within the scatter of the next); then compound 4. At a limit, above all of these: compound 3.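

In this assay this position proves far less tolerant than the flat exchange of methyl for 4-acetoxyphenyl suggested: the step (a 23-fold higher number from compound 2 to compound 4 (1.36 log units; beyond the scatter)) is large, so a low number is not kept across every change here. The step is also not a bare loss of methyl, since the entering ring carries a hydrogen-bond donor and its carbonyl and thiocarbonyl have traded places, and the two changes travel together, so neither can be credited with the rise on its own. Nothing in the data shown gives a reason for this rise.

Still open, from the compounds shown here alone, is what the ring-nitrogen hydrogen does alone, which would take the carbonyl and thiocarbonyl arrangement of compound 2 with that hydrogen, and what the swapped arrangement does alone, which would take the ring of compound 4 with a methyl on its nitrogen. Also open, going by these compounds, is whether an unsubstituted phenyl, a longer chain such as butyl, or a chain ending in a carboxylic acid on that nitrogen stays with compound 1 and compound 2.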